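Triazole amide series: substitution on the triazole ring

This account rests on a few compounds, and the source may have more. Where it says the series, first, only, none or still open, it means among the compounds named here.

Compound 1 `NC(=O)c1ccccc1-c1ccccc1C(=O)NCCCCCCCn1cc(-c2cccnc2)nn1`: 87.9 nM in an assay for inhibition of Nicotinamide phosphoribosyltransferase (Mus musculus), read by fluorescence, with a stated time of 1 h, in the presence of a further agent that is not named here; on this read-out lower numbers stand for stronger inhibition and higher numbers for weaker inhibition
Compound 2 `O=C(NCCCCCCCn1cc(-c2cccnc2)nn1)c1ccccc1-n1ccnn1`: 3.4 nM in this assay

For the measured compounds named here, compound 2 gives the lowest number of the two; the only measured step is a 26-fold lower number from compound 1 to compound 2 (1.41 log units; beyond the scatter). Compound 3 `O=C(NCCCCCCCn1cc(-c2cccnc2)nn1)c1ccccc1-n1cc(CN2CCCCC2)nn1` carries (piperidin-1-yl)methyl in place of hydrogen on an aromatic carbon. Going by the values given here, that measured step concerns exchange of the whole ring, not a substituent on it, so it does not bear directly on this change; no measured step does. With nothing to support a shift either way, compound 3 is expected to give 4 nM in this assay, range 1.2 nM to 14 nM, the estimated step being a 1.2-fold higher number from compound 2 to compound 3 (0.07 log units; within the scatter), within the scatter.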

Compound 3, half-maximal inhibitory concentration: 17.1 nM
Compound 3: middle estimate off by 4.3-fold (0.63 log units), on the low side; measured number outside the range, above it.
By their numbers in this assay, from the lowest: compound 2; then compound 3; then compound 1.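

Substitution on this aromatic carbon of the 1H-1,2,3-triazol-1-yl ring is not neutral in this assay: adding (piperidin-1-yl)methyl in place of hydrogen gives a measurable loss (a 5.0-fold higher number from compound 2 to compound 3 (0.70 log units; beyond the scatter)). The substituted ring still stands ahead of 2-carbamoylphenyl (a 5.1-fold lower number from compound 1 to compound 3 (0.71 log units; beyond the scatter)), so this group gives back only part of the advantage seen with the unsubstituted ring. No data here explain the loss. Still open, going by these compounds, is whether a dimethylamino group on the same methyl, a morpholine ring or a carboxylic acid on this carbon would give a similar number.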